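One Fluorine Moved on a Benzyl Ring

The source may report more compounds than this note shows. Statements on the series, on what has been measured and on what is new or still open speak of the compounds shown alone.

Compound 2 `Fc1ccc(COc2ccc(-c3cc(CN4CCN(Cc5ccc(C(F)(F)F)cc5)CC4)no3)cc2)cc1` and compound 1 `Fc1ccccc1COc1ccc(-c2cc(CN3CCN(Cc4ccc(C(F)(F)F)cc4)CC3)no2)cc1` share a core and differ only in one way: 2-fluorophenyl in place of 4-fluorophenyl on a saturated chain carbon bound to an oxygen on an aromatic ring. In a functional assay on Mahlavu cells (Homo sapiens) for antiproliferative activity, read by sulforhodamine B assay, with a stated time of 72 h (on this read-out higher numbers stand for weaker inhibition and lower numbers for stronger inhibition), compound 2 gives 3100 nM, and compound 1 gives 3100 nM. The step is small: no change at the digits printed from compound 2 to compound 1 (within the scatter). Compound 3 `N#Cc1cccc(COc2ccc(-c3cc(CN4CCN(Cc5ccc(F)cc5)CC4)no3)cc2)c1` has a different core; how it differs from the core of compound 2 is not broken down here. In this assay compound 3 gives 1500 nM. Compound 4 `N#Cc1cccc(COc2ccc(-c3cc(CN4CCN(Cc5ccccc5F)CC4)no3)cc2)c1` is not yet measured and differs from compound 3 in one way: 2-fluorophenyl in place of 4-fluorophenyl on a saturated chain carbon bound to an amine nitrogen in a ring. This is the same kind of change as before, but the place differs: earlier the fluorophenyl sat on a saturated chain carbon bound to an oxygen on an aromatic ring, here on a saturated chain carbon bound to an amine nitrogen in a ring. Since the earlier step was no change at the digits printed from compound 2 to compound 1 (within the scatter), a similarly small step is expected: no change at the digits printed from compound 3 to compound 4 (within the scatter). Compound 4 is therefore estimated at 1500 nM, between 700 nM and 3300 nM.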

Compound 4, half-maximal inhibitory concentration: 2300 nM
Estimate against measurement, compound 4: 1.5-fold (0.19 log units) below; measured number inside the range.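

In this assay the swap to 2-fluorophenyl in place of 4-fluorophenyl gives a 1.5-fold higher number from compound 3 to compound 4 (0.19 log units; within the scatter) and so leaves the two numbers indistinguishable. Set beside the earlier step, the same change behaves alike on both cores: the same change on two cores in this assay, no change at the digits printed (within the scatter) from compound 2 to compound 1 and a 1.5-fold higher number (0.19 log units; within the scatter) from compound 3 to compound 4, 1.5-fold (0.19 log units) apart, within the scatter of two such steps. Going by these compounds alone, this is only two pairs in one assay, with the fluorophenyl in a different place in each pair, so it does not show that the change would stay this small on other cores, nor that the place of the fluorine never matters.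

The compounds shown leave open how far these rings tolerate a group of another kind, such as an amine or a carboxylic acid. They also leave open whether such a group would shift the numbers beyond the usual scatter.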